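Removing a methyl group: from compound 3 to compound 4

This account rests on a few compounds, and the source may have more. Where it says the series, first, only, none or still open, it means among the compounds named here.

Compound 1 `CCc1cccc(NC(=O)CN2CCN(c3ccccn3)CC2)c1`: 26.2%
Compound 2 `Cc1ccc(C2CCN(CC(=O)Nc3cccc(C)c3)CC2)nc1`: "not active" (no number reported)
Compound 3 `Cc1ccc(C2CCN(CC(=O)Nc3cccc(C)c3)CC2)cc1`: "not active" (no number reported)

In an assay on cells for agonist activity at D(4) dopamine receptor (Homo sapiens), read by luminescence and beta-arrestin recruitment, with a stated time of 90 min (on this read-out higher numbers stand for larger maximal responses and lower numbers for smaller maximal responses), compound 1 reaches 26.2%, the only numerical response among the three measured compounds. Compound 2 is recorded as "not active" (no number reported) in this assay. Compound 3 stands in the same place: in this assay compound 3 is recorded as "not active" (no number reported), with no single number, and it is one of two measured compounds for which the assay reported no value at all.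

Compound 4 `Cc1cccc(NC(=O)CN2CCC(c3ccccc3)CC2)c1` differs from compound 3 by hydrogen in place of methyl on an aromatic carbon, a change that reads, cut one bond further out, as 4-methylphenyl to phenyl. Within the data shown here, no step between measured compounds is available, so nothing fixes the size of this change in this assay. Since compound 3 gives "not active" (no number reported), the expectation is that compound 4 also shows at most a small maximal response, with any difference from compound 3 staying within the scatter of this assay. Compound 4 is therefore estimated at 10%, with a range from 0% to 30%, and a real chance that the assay again reports no number.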

Compound 4, largest response reached (Emax), in percent of the reference or control that the assay uses: 14%
Compound 4: the middle estimate sits 4 percentage points below what was measured, and the stated range covers the measured number.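

Among these compounds, compound 3 is recorded as "not active" (no number reported) and compound 4 gives 14% on this read-out, so no step between compound 3 and compound 4 can be read. On these data alone, what the change from 4-methylphenyl to phenyl does to the maximal response stays open. Nothing available bears on this result.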